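This account rests on a few compounds, and the source may have more. Where it says the series, first, only, none or still open, it means among the compounds named here.

Compound 3 `CCCSc1nc2nc(C)cc(Nc3cc(-c4ccccc4)[nH]n3)n2n1` carries a propylsulfanyl group on the shared core. In a functional assay on PC-9 cells (Homo sapiens) for inhibition, read by MTT assay, with a stated time of 72 h (on this read-out lower numbers stand for stronger inhibition and higher numbers for weaker inhibition), compound 3 reaches only the limit of the assay, > 50000 nM. Two close relatives give real numbers: compound 1 `Cc1cc(Nc2cc(-c3ccccc3)[nH]n2)n2nc(SCc3cccc(Br)c3)nc2n1` gives 8900 nM, and compound 2 `Cc1cc(Nc2cc(-c3ccccc3)[nH]n2)n2nc(SCCc3ccccc3)nc2n1` gives 4930 nM. Cutting their aromatic rings down to short chains weakened inhibition, by an at least 5.6-fold higher number from compound 1 to compound 3 (0.74 log units; beyond the scatter) and by an at least 10-fold higher number from compound 2 to compound 3 (1.00 log units; beyond the scatter). Compound 4 `Cc1cc(Nc2cc(-c3ccccc3)[nH]n2)n2nc(SCC3CCCCC3)nc2n1` differs from compound 3 by cyclohexyl in place of ethyl on a saturated chain carbon bound to a sulfur. Because compound 3 sits at the limit of > 50000 nM in this assay, at which 1 of the 3 values shown sits, restoring a ring, here a six-membered non-aromatic one, is expected to bring a lower number, and the step is estimated at an at least 4.1-fold lower number from compound 3 to compound 4 (0.61 log units; beyond the scatter). Compound 4 is therefore expected to give about 12000 nM, within 4000 nM to 45000 nM.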

Compound 4, half-maximal inhibitory concentration: > 50000 nM
Compound 4 gave a limit, no number (the forecaster's own chance of this, stated with the estimate: 30%); middle value at least 4.1-fold (0.61 log units) from the limit.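

Having a ring on the chain is not enough at this position: cyclohexyl in place of the aromatic groups gives an at least 10-fold higher number from compound 2 to compound 4 (1.00 log units; beyond the scatter) and an at least 5.6-fold higher number from compound 1 to compound 4 (0.74 log units; beyond the scatter). Of the four compounds shown, only compound 1 and compound 2, which carry an aromatic ring on the chain, give real numbers. Compound 3 and compound 4 each stop at a limit, so the step between them cannot be read: the limit of > 50000 nM in this assay, at which 2 of the 4 values shown sit.

Still open, as far as these compounds go, is whether a pyridine ring on the same chain would give a real number. So is whether an amine or a carboxylic acid on the aromatic ring would.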